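A few compounds are considered here, and "the series" means these few. Any claim that something is new, unique, unknown or untested is made for them only; others in the source may bear on it.

In a functional assay on the whole organism for inhibition, with Rattus norvegicus as the target, read by paw edema, with stated times of 30 min and 4 h, at a dose of 0.28 mmol/kg by the oral route (a lower number here means less inhibition, a higher number more inhibition at the dose given (going by the name of the read-out)), compound 1 `CCNC(=O)c1nc(-c2cc(OC)c(OC)c(OC)c2)n(-c2ccc(OC)cc2)n1` gives 58%, and compound 2 `COc1ccc(-n2nc(C(=O)Nc3ccc(C)cc3)nc2-c2cc(OC)c(OC)c(OC)c2)cc1` gives 58%, so that no change at the digits printed from compound 1 to compound 2 (within the scatter). Compound 3 `COc1ccc(-n2nc(C(=O)Nc3ccc(O)cc3)nc2-c2cc(OC)c(OC)c(OC)c2)cc1` gives 37%, the lowest of the three numbers, with a number 21 percentage points lower from compound 1 to compound 3 (beyond the scatter) and a number 21 percentage points lower from compound 2 to compound 3 (beyond the scatter). Compound 4 `COc1ccc(-n2nc(C(=O)Nc3ccccc3)nc2-c2cc(OC)c(OC)c(OC)c2)cc1` has not yet been measured in this assay. The difference between compound 3 and compound 4 is hydrogen in place of hydroxy on an aromatic carbon. Among the measured compounds shown here, two measured steps bear on this change. The step in which a number 21 percentage points lower from compound 2 to compound 3 (beyond the scatter) is the closest, since there the hydroxy came in on the same aromatic carbon in place of methyl and the number fell. The step in which no change at the digits printed from compound 1 to compound 2 (within the scatter) shows that an aryl amide without a hydroxy stands at the same level as the ethyl amide of compound 1. Hydrogen in place of hydroxy is therefore expected to give back most of that loss, and the expected step is a number 18 percentage points higher from compound 3 to compound 4 (beyond the scatter), a rise of moderate size. Compound 4 is estimated at 55%, within a range from 40% to 68%.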

Compound 4, a percentage reported as inhibition, in the whole organism at one dose (the size of the read-out at that dose, not a potency): 50%
The estimate for compound 4 lay 5 percentage points above the measured number, within the range that was stated.
By their numbers in this assay, from the lowest: compound 3; then compounds 4, 1 and 2 (each within the scatter of the next).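

In this assay, among the compounds shown here, taking the hydroxy off the 4-hydroxyphenyl group gives a number 13 percentage points higher from compound 3 to compound 4 (beyond the scatter) and so restores much of the number, a comparison that the earlier steps could make only against methyl. For the compounds shown here, with the unsubstituted phenyl amide now in hand, a number 8 percentage points lower from compound 2 to compound 4 (within the scatter) and a number 8 percentage points lower from compound 1 to compound 4 (within the scatter) show that neither hydrogen in place of methyl at this ring carbon nor phenyl in place of ethyl on the amide nitrogen moves the result beyond the scatter, which leaves hydroxy as the only one of these changes that lowers the number. Nothing measured here accounts for the effect of the hydroxy.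

As far as these compounds go, it remains open whether other groups at this ring carbon, such as methoxy, an amine or a carboxylic acid, would lower the number as hydroxy does. Since each compound was read at a single dose, these numbers also leave their relative potency open.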